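The source may hold more compounds than are shown below. What is called first, only, known or untested is meant among the compounds shown, and "the series" means these compounds.

Of the compounds shown here, three on a shared core have been tested in a functional assay on Caco-2 cells (Homo sapiens) for antiproliferative activity, read by MTT assay, with a stated time of 48 h; a higher number here means a weaker inhibitor, a lower number a stronger inhibitor. Compound 1 `CCCc1nc2cc(C(=O)N3CCC4(CC3)CC(=O)N(c3ccc(C(F)(F)F)cc3)C4)cc(C)c2[nH]1` gives > 10000 nM, which is a limit of the assay and not a number. Compound 2 `O=C(c1ccc2[nH]c(-c3ccccc3)nc2c1)N1CCC2(CC1)CC(=O)N(c1ccc(C(F)(F)F)cc1)C2` gives a real number, 5420 nM. Compound 3 `CC(C)c1ccc(-c2nc3cc(C(=O)N4CCC5(CC4)CC(=O)N(c4ccc(C(F)(F)F)cc4)C5)ccc3[nH]2)cc1` gives > 10000 nM, which is again a limit. Compound 3 therefore stands at the limit of > 10000 nM in this assay, at which 2 of the 3 values shown sit, and its true value is not known.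

Compound 4 `O=C(c1ccc2[nH]c(-c3ccncc3)nc2c1)N1CCC2(CC1)CC(=O)N(c1ccc(C(F)(F)F)cc1)C2` has not yet been measured. It carries pyridin-4-yl in place of the 4-isopropylphenyl of compound 3, on an aromatic carbon of the five-membered ring with two nitrogens: pyridin-4-yl in place of 4-isopropylphenyl on an aromatic carbon.

Among the compounds with values here, only one measured step bears on this change, the one that brought the isopropyl group in, and it is an at least 1.8-fold higher number from compound 2 to compound 3 (0.26 log units; that floor lies within the scatter). Compound 4 no longer has that isopropyl group, so a move to a lower number in this assay is expected. That move should be modest, since the measured step gives only a floor and no data yet test a pyridine ring. Expressed as a step, the expected change is an at least 1.4-fold lower number from compound 3 to compound 4 (0.15 log units; that floor lies within the scatter). For compound 4 the estimated value is 7000 nM, with an expected range from 3000 nM to 14000 nM.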

Compound 4, half-maximal inhibitory concentration: > 10000 nM
Compound 4 was reported as a limit; the forecaster's own chance of this, stated with the estimate: 35%; at least 1.4-fold (0.15 log units) between middle value and limit.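

In this assay, within the data shown here, the swap of 4-isopropylphenyl for pyridin-4-yl on this aromatic carbon does not bring a real number back, so compound 2, with its plain phenyl, remains the only one of the three compounds varied here to give one. Adding a ring nitrogen to that phenyl, with no added isopropyl group, gives an at least 1.8-fold higher number from compound 2 to compound 4 (0.26 log units; that floor lies within the scatter), so a larger group and a ring with a hetero atom both end at the limit, and neither size can be told from that floor. The step between the two limits of compound 3 and compound 4 cannot be read, and the firmest fact is where the values gather: the limit of > 10000 nM in this assay, at which 3 of the 4 values shown sit.

As far as these compounds go, the true values of compound 3 and compound 4 remain unknown, so these data cannot rank the two rings against each other. They also do not tell how a phenyl ring carrying a fluorine, an amine or a carboxylic acid would behave on this carbon, or whether any such group would give a lower number than compound 2.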